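The source may hold more compounds than are shown below. What is called first, only, known or untested is meant among the compounds shown, and "the series" means these compounds.

Measured compounds in a functional assay on MCF7 cells (Homo sapiens) for antiproliferative activity, read by sulforhodamine B assay, with a stated time of 48 h; a lower number here means a stronger inhibitor, a higher number a weaker inhibitor:

compound 1 `CN1CCN(c2ccc(S(=O)(=O)Oc3ccc(F)cc3)cc2)C1=O`: > 100000 nM (a limit of the assay)
compound 2 `CN1CCN(c2ccc(S(=O)(=O)Oc3ccc(Cl)cc3)cc2)C1=O`: > 100000 nM (a limit of the assay)
compound 3 `CCCN1CCN(c2ccc(S(=O)(=O)Oc3ccc(F)cc3)cc2)C1=O`: 33000 nM

Compound 1 sits at the limit of this assay. Compound 2 sits at the same limit. Compound 3 is the only one of the three with a number.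

The step from compound 1 to compound 3 is ethyl in place of hydrogen on a saturated chain carbon bound to an amide-type nitrogen in a ring; it reads an at least 3.0-fold lower number from compound 1 to compound 3 (0.48 log units; beyond the scatter).

The change from compound 1 to compound 2 is chloro in place of fluoro on an aromatic carbon; it reads a step that the two limits leave unreadable from compound 1 to compound 2, the reason being (the limit of > 100000 nM in this assay, at which 2 of the 3 values shown sit).

Compound 4 `CCCN1CCN(c2ccc(S(=O)(=O)Oc3ccc(Cl)cc3)cc2)C1=O` is not yet measured. It differs from compound 3 by chloro in place of fluoro on an aromatic carbon, the same change as from compound 1 to compound 2, at the same place. Among the compounds with values here, the one earlier instance gives no readable size, so the expectation for compound 4 rests on compound 3 alone, whose value is 33000 nM; the step from compound 3 to compound 4 is expected to be a 1.1-fold lower number from compound 3 to compound 4 (0.04 log units; within the scatter). Compound 4 is therefore estimated at 30000 nM, with a likely range from 10000 nM to 100000 nM.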

Compound 4, half-maximal inhibitory concentration: 18000 nM
Estimate against measurement, compound 4: 1.7-fold (0.22 log units) above; low and high end bracket the measured number.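

In this assay, ethyl in place of hydrogen on the saturated chain carbon bound to the amide-type nitrogen reads an at least 5.5-fold lower number from compound 2 to compound 4 (0.74 log units; beyond the scatter), which is the second instance of that change. Both instances point the same way, but their sizes cannot be set against each other: the same change on two cores in this assay, an at least 3.0-fold lower number (0.48 log units; beyond the scatter) from compound 1 to compound 3 and an at least 5.5-fold lower number (0.74 log units; beyond the scatter) from compound 2 to compound 4; the limit leaves it open whether they differ

Chloro in place of fluoro reads a 1.8-fold lower number from compound 3 to compound 4 (0.26 log units; within the scatter), so compounds 3 and 4 do not separate, and the same swap between compounds 1 and 2 cannot be read: the limit of > 100000 nM in this assay, at which 2 of the 4 values shown sit.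

The compounds shown leave open whether a longer chain in the same place, such as hexyl, or an amine or carboxylic acid carried on that chain, would give a lower number than compounds 3 and 4. They also leave open whether bromo or methoxy in place of the chloro would separate from these two halogens on the aromatic ring.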